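Naphthalen-1-yl for 3-methylphenyl on the shared core

The compounds below may be only part of what the source reports. "The series", "measured", "known", "first", "only" and "open" are said of these compounds alone.

Compound 3 `Cc1cccc(-c2cn3ccnc3c(-c3ccc4ncn(Cc5ccccc5)c4c3)n2)c1` carries a 3-methylphenyl group and gives 2.46% in a functional assay on UACC-62 cells (Homo sapiens) for inhibition, read by sulforhodamine B assay, with a stated time of 48 h, tested at 10 uM; on this read-out lower numbers stand for less inhibition and higher numbers for more inhibition at the one concentration tested (going by the name of the read-out). It stands lowest of the three numbers measured. Compound 2 `CCc1ccc(-c2cn3ccnc3c(-c3ccc4ncn(Cc5ccccc5)c4c3)n2)cc1`, with 4-ethylphenyl in the same place, gives 24.9%, and compound 1 `c1ccc2c(-c3cn4ccnc4c(-c4ccc5ncn(C6CCCCC6)c5c4)n3)cccc2c1`, which already carries naphthalen-1-yl but a cyclohexyl rather than a benzyl group elsewhere on the shared core, gives 16.7%.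

Compound 4 `c1ccc(Cn2cnc3ccc(-c4nc(-c5cccc6ccccc56)cn5ccnc45)cc32)cc1` has not yet been measured. It differs from compound 3 by naphthalen-1-yl in place of 3-methylphenyl on an aromatic carbon.

Going by the values given here, the only measured step at this aromatic carbon is a number 22.4 percentage points lower from compound 2 to compound 3 (beyond the scatter), which shows that changing the aryl group here can shift inhibition by a modest amount, beyond the scatter. Among the compounds with values here, no step leads directly to compound 4; compound 1 shows only that a naphthalen-1-yl compound can reach the middle of the present range. Some recovery from the low number of compound 3 toward the values of compound 1 and compound 2 is therefore expected, but of uncertain size.

Compound 4 is estimated at 15%, with a range from 2% to 35%, meaning an expected step of a number 12.5 percentage points higher from compound 3 to compound 4 (beyond the scatter).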

Compound 4, a percentage reported as inhibition, at one concentration (the size of the read-out at that concentration, not a potency): 12.9%
Beside the measured number, compound 4's estimate is 2.1 percentage points above it; measured number inside the range.
By their numbers in this assay, from the lowest: compound 3; then compounds 4, 1 and 2 (each within the scatter of the next, the first and the last beyond it).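

In this assay, naphthalen-1-yl in place of 3-methylphenyl on this aromatic carbon gives a number 10.4 percentage points higher from compound 3 to compound 4 (beyond the scatter), and naphthalen-1-yl in place of 4-ethylphenyl gives a number 12 percentage points lower from compound 2 to compound 4 (beyond the scatter), so with benzyl on the aromatic nitrogen the three aryl groups now give three separate levels, with naphthalen-1-yl in the middle. The second ring of naphthalen-1-yl therefore neither abolishes the read-out nor matches 4-ethylphenyl here, and the series no longer rests on a single step at this carbon. Benzyl in place of cyclohexyl on the aromatic nitrogen gives a number 3.8 percentage points lower from compound 1 to compound 4 (within the scatter), so with naphthalen-1-yl in place this exchange shows no readable change.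

No measured evidence accounts for these differences among the aryl groups.

Going by these compounds, what an aryl group bearing an amine or a carboxylic acid would give at this carbon stays open, as does a longer chain in place of benzyl on the aromatic nitrogen. The gap between 3-methylphenyl and 4-ethylphenyl also remains unassigned, since those groups differ in both chain and placement, and a single-concentration read-out gives no potency for any of the compounds.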